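The compounds below may be only part of what the source reports. "The series", "measured", "known", "first", "only" and "open" are said of these compounds alone.

Measured in a functional assay on HCT-116 cells (Homo sapiens) for inhibition, read by MTT assay, with a stated time of 48 h; on this read-out lower numbers stand for stronger inhibition and higher numbers for weaker inhibition:
- compound 1 `C[Se]c1ccc(N(C)c2nc(C3CC3)nc3ccccc23)cc1`: 15 nM
- compound 2 `COc1ccc(N(C)c2nc(C)nc3ccccc23)cc1C(=O)NCC[Se]C#N`: 313 nM
- compound 3 `Cc1nc(N(C)c2ccc(OCC[Se]C#N)cc2)c2ccccc2n1`: 2290 nM

Compound 2 holds the middle place of the three numbers, with a lower number than compound 3 and a higher number than compound 1. Both gaps lie beyond the scatter.

The next compound to consider is compound 4 `COc1ccc(N(C)c2nc(C)nc3ccccc23)cc1C[Se]C#N`, which differs from compound 2 as follows: a group of 4 heavy atoms (2 carbon, 1 nitrogen, 1 selenium; no ring) in place of a group of 8 heavy atoms (4 carbon, 2 nitrogen, 1 oxygen, 1 selenium; no ring), on an aromatic carbon. The change sits ortho to a methoxy group and meta to a large group.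

Going by the values given here, no two measured compounds differ in one place only, so the series gives no direct measure of this change. The wide gap between compound 1 at 15 nM and compound 3 at 2290 nM also argues for a broad range. No step beyond the scatter is expected in this assay, with only a slight lean toward a lower number. The expected step is a 1.6-fold lower number from compound 2 to compound 4 (0.19 log units; within the scatter). The estimate for compound 4 is 200 nM, with an expected range of 40 nM to 1000 nM.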

Compound 4, half-maximal inhibitory concentration: 113 nM
The estimate for compound 4 lay 1.8-fold (0.25 log units) above the measured number; measured number inside the range.
By their numbers in this assay, from the lowest: compound 1; then compound 4; then compound 2; then compound 3.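

In this assay, replacing the group of 8 heavy atoms with the group of 4 heavy atoms on this aromatic carbon, ortho to a methoxy group, gives a 2.8-fold lower number from compound 2 to compound 4 (0.44 log units; beyond the scatter). The larger group is therefore not required for activity in this series, and the smaller group is the better of the two at this position. The change also takes away the hydrogen-bond donor and a carbonyl along with chain length, and no data bear on which of these differences accounts for the step.

This single step leaves open how the number responds to other groups on this carbon, such as a longer chain without the carbonyl or an amine. It also leaves open whether the step would hold with the methoxy group removed or on the core of compound 1.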